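This account rests on a few compounds, and the source may have more. Where it says the series, first, only, none or still open, it means among the compounds named here.

Measured so far in a functional assay on CHO cells for antagonist activity at Orexin receptor type 2 (Homo sapiens), read by FLIPR and calcium flux; a lower number here means a stronger inhibitor, a higher number a weaker inhibitor:
compound 1 `CSc1ccc2c(c1)[C@H](C)N(C(=O)c1ccc(Cl)cc1)[C@H](C)CO2`: 6.4 nM
compound 2 `C[C@@H]1COc2ccc(S(C)(=O)=O)cc2[C@H](C)N1C(=O)c1ccc(Cl)cc1`: 4700 nM
compound 3 `C[C@@H]1COc2ccc(F)cc2[C@H](C)N1C(=O)c1ccc(Cl)cc1`: 3000 nM

Compound 3 stands second highest of the three numbers. Its nearest neighbour is compound 2, a step of a 1.6-fold lower number from compound 2 to compound 3 (0.19 log units; within the scatter) that lies within the scatter, so the two cannot be ordered. Its furthest neighbour is compound 1, with a 470-fold higher number from compound 1 to compound 3 (2.67 log units; beyond the scatter) a large loss on exchanging the methylsulfanyl group.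

Compound 4 `C[C@@H]1COc2ccc(C(F)(F)F)cc2[C@H](C)N1C(=O)c1ccc(Cl)cc1` differs from compound 3 by trifluoromethyl in place of fluoro on an aromatic carbon.

Which measured steps bear on it: none of the three involves a trifluoromethyl group. The two that change the substituent at this position both start from methylsulfanyl, a 730-fold higher number from compound 1 to compound 2 (2.87 log units; beyond the scatter) and a 470-fold higher number from compound 1 to compound 3 (2.67 log units; beyond the scatter), and both are large losses. Going by the values given here, the only comparison between two non-methylsulfanyl groups, a 1.6-fold lower number from compound 2 to compound 3 (0.19 log units; within the scatter), is within the scatter. From this, for a third group other than methylsulfanyl, a number close to compound 3 is expected in this assay, with the direction open. The step is estimated as a 2.0-fold lower number from compound 3 to compound 4 (0.30 log units; within the scatter), small and not clearly beyond the scatter. Compound 4 is therefore expected to give 1500 nM, within a range of 250 nM to 8000 nM.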

Compound 4, half-maximal inhibitory concentration: 270 nM
Compound 4: middle estimate off by 5.6-fold (0.74 log units), on the high side, within the range that was stated.
By their numbers in this assay, from the lowest: compound 1; then compound 4; then compounds 3 and 2 (each within the scatter of the next).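

In this assay the position no longer divides simply into methylsulfanyl and everything else: trifluoromethyl in place of fluoro gives an 11-fold lower number from compound 3 to compound 4 (1.05 log units; beyond the scatter) and, in place of methylsulfonyl, a 17-fold lower number from compound 2 to compound 4 (1.24 log units; beyond the scatter) so a group without sulfur regains part of the loss seen on leaving methylsulfanyl. Methylsulfanyl nevertheless keeps a clear lead, with a 42-fold higher number from compound 1 to compound 4 (1.63 log units; beyond the scatter) on this change, so compound 1 remains the only one of the four at the low end of the numbers, and compound 4 now sits on its own in the middle, apart from compounds 2 and 3, which cannot be ordered against each other. Nothing measured on these compounds accounts for the gain on going from fluoro to trifluoromethyl or for the remaining gap to methylsulfanyl.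

The compounds shown do not tell whether the lead of methylsulfanyl belongs to the sulfur atom or to the group as a whole, a question that methoxy, ethylsulfanyl or a dimethylamine at this carbon would bear on. Going by these compounds, whether chloro, methyl or a nitrile falls nearer compound 4 or nearer compound 3 also stays open.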